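Cytotoxicity of an Amide Series: Isobutoxy Replacing Phenyl

The source may hold more compounds than are shown below. What is called first, only, known or untested is meant among the compounds shown, and "the series" means these compounds.

Compound 1 `CC(C)COc1cccc(-c2ccc(C(=O)N(Cc3cccc(OCCCCCC(=O)O)c3)C(C)C)cc2)c1`: in an ADME assay on BJ cells (Homo sapiens) for cytotoxicity, read by CellTiter-Glo and resazurin assay, with a stated time of 72 h (on this read-out lower numbers stand for an effect already at smaller amounts and higher numbers for an effect only at larger amounts of compound), compound 1 gives > 26000 nM, a limit of the assay.
Compound 2 `CCOC(=O)CCCCCOc1cccc(CN(C(=O)c2ccc(-c3cccc4ccccc34)cc2)C(C)C)c1`: in this assay compound 2 gives > 26000 nM, also a limit.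
Compound 3 `CCOC(=O)CCCCCOc1cccc(CN(C(=O)c2ccc(-c3cccc(-c4ccccc4)c3)cc2)C(C)C)c1`: in this assay compound 3 gives > 26000 nM, again a limit.

All three measured compounds sit at the same limit, so compound 3 stands nowhere in particular among them: no number separates it from compound 1 or compound 2. Going by the values given here, the one step that connects measured compounds, a step that the two limits leave unreadable from compound 2 to compound 3, cannot be read because both ends are limits. Among the compounds with values here, the only evidence is the limit of > 26000 nM in this assay, at which 3 of the 3 values shown sit, which every measured value shares.

Compound 4 `CCOC(=O)CCCCCOc1cccc(CN(C(=O)c2ccc(-c3cccc(OCC(C)C)c3)cc2)C(C)C)c1` differs from compound 3 by isobutoxy in place of phenyl on an aromatic carbon; cut one bond further out, the change reads 3-phenylphenyl to 3-(isobutoxy)phenyl, and the group sits meta to a large group. Compound 1 already carries an isobutoxy group on its outer ring and also reaches only the limit, which supports the expectation that this change leaves the read-out where it is.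

Compound 4 is therefore expected to give 30000 nM in this assay, with a range from 15000 nM to 100000 nM. The expected step that the limit leaves unreadable from compound 3 to compound 4 is no step beyond the scatter, and most likely compound 4 again returns only the limit.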

Compound 4, half-maximal effective concentration: > 26000 nM
Compound 4: only a limit was reported; the forecaster's own chance of this, stated with the estimate: 85%; the middle value does not contradict the limit.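

In this assay compound 4 gives > 26000 nM, again a limit. The steps to compound 4 from compound 1, compound 2 and compound 3 therefore cannot be read. The compounds shown leave open at what concentration, if any, a cytotoxic effect would appear and whether any of these changes alters it: the limit of > 26000 nM in this assay, at which 4 of the 4 values shown sit.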